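This account rests on a few compounds, and the source may have more. Where it says the series, first, only, none or still open, it means among the compounds named here.

Three compounds of one family have been examined so far. Compound 1 `O=C1Nc2ccccc2/C1=N/NC(=S)Nc1ccc(-n2cccn2)cc1`, compound 2 `O=C(N/N=C1\C(=O)Nc2ccccc21)Nc1ccccc1` and compound 3 `O=C1Nc2ccc(F)cc2/C1=N/NC(=S)Nc1ccccc1` share a core that carries a hydrazone linked to a thiourea or urea. In an ADME assay on RD cells (Homo sapiens) for cytotoxicity (a lower number here means that less compound is tolerated, a higher number that more compound is tolerated), compound 1 gives > 25000 nM, which is a limit of the assay and not a number. In this assay compound 2 likewise gives > 25000 nM, again a limit rather than a number. Compound 3 in this assay gives > 25000 nM, once more a limit. For the measured compounds named here, compound 3 therefore stands where every value so far stands, because of the limit of > 25000 nM in this assay, at which 3 of the 3 values shown sit. Going by the values given here, no step between two measured compounds can be drawn from these limits.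

Compound 4 `O=C1Nc2ccc(Br)cc2/C1=N/NC(=S)Nc1ccccc1` is not yet measured. It differs from compound 3 in one place: bromo in place of fluoro on an aromatic carbon. With all three measured values sitting at the limit, no step beyond the scatter is expected in this assay for the change from compound 3 to compound 4, and a step that the limit leaves unreadable from compound 3 to compound 4 is the expected step. Compound 4 is therefore expected to give about 30000 nM in this assay, within a range from 12000 nM to 80000 nM, most likely reported again as a limit.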

Compound 4, half-maximal cytotoxic concentration: > 25000 nM
Compound 4: a limit, no number; the forecaster's own chance of this, stated with the estimate: 75%; the middle value is on the limit's open side.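

No step can be read between compound 3 and compound 4 in this assay, because both values are limits and not numbers: the limit of > 25000 nM in this assay, at which 4 of the 4 values shown sit. The compounds shown leave open how much of any of them the cells tolerate, and whether bromo and fluoro differ at all in this respect.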